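The source may report more compounds than this note shows. Statements on the series, on what has been measured and on what is new or still open speak of the compounds shown alone.

Measured compounds:
Compound 1 `CN(CCC#N)C[C@H]1CN(c2ccc(-n3cc(-c4ccccn4)cn3)c(F)c2)C(=O)O1`: in an ADME assay on HEK293-A cells (Homo sapiens) for cytotoxicity, read by MTT assay, with a stated time of 48 h (on this read-out higher numbers stand for weaker inhibition and lower numbers for stronger inhibition), compound 1 reaches only the limit > 400 ug/mL.
Compound 2 `CN1CCN(C[C@H]2CN(c3ccc(-n4cc(-c5ccccn5)cn4)c(F)c3)C(=O)O2)CC1`: in this assay compound 2 gives 70 ug/mL.

Going by the values given here, compound 2 holds the only true number of the pair. Compound 1 sits at the limit of > 400 ug/mL in this assay, at which 1 of the 2 values shown sits. Compound 3 `CCN1CCN(C[C@H]2CN(c3ccc(-n4cc(-c5ccccn5)cn4)c(F)c3)C(=O)O2)CC1` differs from compound 2 by methyl in place of hydrogen on a saturated chain carbon bound to an amine nitrogen in a ring. Among the compounds with values here, the single measured step, an at least 5.7-fold lower number from compound 1 to compound 2 (0.75 log units; beyond the scatter), exchanged the whole amine group and gives little guidance for so small an extension on the ring nitrogen. Compound 3 is therefore expected to stay within the scatter, estimated at 70 ug/mL with a range of 35 ug/mL to 140 ug/mL. The expected step of no change at the digits printed from compound 2 to compound 3 (within the scatter) is within the scatter.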

Compound 3, half-maximal inhibitory concentration: 99 ug/mL
For compound 3 the middle estimate is 1.4-fold (0.15 log units) below the measured one, within the range that was stated.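

On the saturated chain carbon bound to an amine nitrogen in a ring, methyl in place of hydrogen gives in this assay a 1.4-fold higher number from compound 2 to compound 3 (0.15 log units; within the scatter), so 4-methylpiperazin-1-yl and 4-ethylpiperazin-1-yl cannot be told apart here. 4-Ethylpiperazin-1-yl in place of (2-cyanoethyl)(methyl)amino gives an at least 4.0-fold lower number from compound 1 to compound 3 (0.60 log units; beyond the scatter), so both piperazine groups now stand apart from the open-chain amine. Both steps from compound 1 start from a limit: the limit of > 400 ug/mL in this assay, at which 1 of the 3 values shown sits.

Open, going by these compounds, is whether a propyl chain or a hydroxyethyl group on that ring nitrogen stays within the same range. Also open, on these data alone, is how a morpholine in place of the piperazine would read.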